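The source may report more compounds than this note shows. Statements on the series, on what has been measured and on what is new or still open speak of the compounds shown alone.

Among the measured compounds shown here, in a functional assay on NCI-H23 cells (Homo sapiens) for cytotoxicity, read by sulforhodamine B assay, with a stated time of 72 h (a lower number here means a stronger inhibitor of growth, a higher number a weaker inhibitor of growth), compound 3 `CCCCCCCCC(=O)N1c2ccccc2CCC1C(=O)Nc1ccccc1O` gives 55800 nM, the second highest of the three numbers measured so far; compound 1 `CC(=O)N1c2ccccc2CCC1C(=O)Nc1ccccc1O` gives 65700 nM, and compound 2 `O=C(Nc1ccccc1O)C1CCc2ccccc2N1C(=O)c1ccc(Cl)cc1` gives 19200 nM. Among the measured steps, a 1.2-fold lower number from compound 1 to compound 3 (0.07 log units; within the scatter), a 3.4-fold lower number from compound 1 to compound 2 (0.53 log units; beyond the scatter), and a 2.9-fold higher number from compound 2 to compound 3 (0.46 log units; beyond the scatter). Compound 4 `O=C(Nc1ccccc1O)C1CCc2ccccc2N1` differs from compound 3 by hydrogen in place of octylcarbonyl on a nitrogen on an aromatic ring in a ring. For the measured compounds named here, no measured step removes the acyl group altogether, and the steps that swap one acyl group for another shift the number by at most a modest amount. Only a small difference is therefore expected for compound 4, with a 1.1-fold higher number from compound 3 to compound 4 (0.03 log units; within the scatter). The estimate for compound 4 is 60000 nM, with a range from 20000 nM to 150000 nM.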

Compound 4, concentration for 50% growth inhibition: 2230 nM
The estimate for compound 4 lay 27-fold (1.43 log units) above the measured number; the measured number lies below the stated range.
By their numbers in this assay, from the lowest: compound 4; then compound 2; then compounds 3 and 1 (each within the scatter of the next).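

Taking the acyl group off this ring nitrogen altogether counts for far more than swapping one acyl group for another: the change gives a 25-fold lower number from compound 3 to compound 4 (1.40 log units; beyond the scatter), a 29-fold lower number from compound 1 to compound 4 (1.47 log units; beyond the scatter) and an 8.6-fold lower number from compound 2 to compound 4 (0.93 log units; beyond the scatter). The lower number with hydrogen therefore holds against all three acyl groups, the octylcarbonyl, the acetyl and the (4-chlorophenyl)carbonyl. No measurement here explains this difference.

The compounds shown leave open whether the lower number needs hydrogen on this nitrogen, or whether a methyl or benzyl group, which has no carbonyl, would give a similar number.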